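Chloro in place of fluoro: an expected small step

The source may report more compounds than this note shows. Statements on the series, on what has been measured and on what is new or still open speak of the compounds shown alone.

In a functional assay on T98G cells (Homo sapiens) for inhibition, read by MTT assay, with a stated time of 72 h (on this read-out higher numbers stand for weaker inhibition and lower numbers for stronger inhibition), compound 1 `CC1(C)CC(NC(=S)NCc2ccccc2)c2cc(F)ccc2O1` gives 40000 nM and compound 2 `CC1(C)CC(NC(=S)Nc2cccc(C#N)c2)c2cc(F)ccc2O1` gives 39000 nM so compound 2 stands level with compound 1. Compound 3 `CC1(C)CC(NC(=S)Nc2ccc([N+](=O)[O-])cc2)c2cc(Br)ccc2O1` gives 5000 nM which is a lower number than compound 2 shows. Compound 4 `CC1(C)CC(NC(=S)Nc2cccc(C#N)c2)c2cc(Cl)ccc2O1` has not yet been measured. It differs from compound 2 by chloro in place of fluoro on an aromatic carbon and carries chloro in place of fluoro on an aromatic carbon.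

Within the data shown here, the one measured step that changes a single place is a 1.0-fold lower number from compound 1 to compound 2 (0.01 log units; within the scatter) and it lies within the scatter. It puts 3-cyanophenyl in place of benzyl on an amide-type nitrogen and leaves the fluoro untouched, so it does not test the halogen. Compound 3 differs from compound 2 in more than one place, so its lower number cannot be tied to the halogen alone. In this assay the estimated change is a 1.3-fold lower number from compound 2 to compound 4 (0.11 log units; within the scatter) and no shift beyond the scatter is expected. For compound 4 30000 nM is the expected value, with 10000 nM to 70000 nM as its estimated range.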

Compound 4, half-maximal inhibitory concentration: 10000 nM
Estimate against measurement, compound 4: 3.0-fold (0.48 log units) above; measured number inside the range.
By their numbers in this assay, from the lowest: compounds 3 and 4 (each within the scatter of the next); then compounds 2 and 1 (each within the scatter of the next).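

In this assay the exchange of fluoro for chloro on this aromatic carbon gives a 3.9-fold lower number from compound 2 to compound 4 (0.59 log units; beyond the scatter) and so moves the number beyond the scatter, though only modestly. This is the first single-place change shown to do so, and the first to test the halogen, since the earlier step altered only the group on the amide-type nitrogen and left the fluoro untouched. Nothing available explains why this exchange lowers the number.

Going by these compounds, whether the same exchange would give a similar step with the benzyl of compound 1 on the amide-type nitrogen remains open. So does the outcome of placing a methoxy or an amine on this aromatic carbon, with the rest of compound 4 unchanged.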